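Methyl for Methoxy on the Aryl Group of a Quinoline Amide

A few compounds are considered here, and "the series" means these few. Any claim that something is new, unique, unknown or untested is made for them only; others in the source may bear on it.

Compound 1 `COc1cc2c(Oc3ccc(NC(=O)c4cc(-c5ccc(C)cc5)nc5ccccc45)cc3F)ccnc2cc1OCCCN1CCC(C)CC1`: 880 nM
Compound 2 `COc1cc2c(Oc3ccc(NC(=O)c4cc(-c5cccc(Cl)c5)nc5ccc(F)cc45)cc3F)ccnc2cc1OCCCN1CCC(C)CC1`: 60 nM
Compound 3 `COc1cccc(-c2cc(C(=O)Nc3ccc(Oc4ccnc5cc(OCCCN6CCC(C)CC6)c(OC)cc45)c(F)c3)c3cc(F)ccc3n2)c1`: 840 nM

In a functional assay on NCI-H460 cells (Homo sapiens) for cytotoxicity, read by MTT assay, with a stated time of 72 h (on this read-out lower numbers stand for stronger inhibition and higher numbers for weaker inhibition), compound 3 gives 840 nM, the second highest of the three numbers. Its nearest neighbour is compound 1, whose value of 880 nM lies within the scatter of it; the furthest is compound 2, whose 60 nM sits well below it. Within the data shown here, the one single-point step among the measured compounds is a 14-fold higher number from compound 2 to compound 3 (1.15 log units; beyond the scatter), which shows that the identity of the substituent on the pendant phenyl ring can move this read-out a long way.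

Compound 4 `COc1cc2c(Oc3ccc(NC(=O)c4cc(-c5ccc(C)cc5)nc5ccc(F)cc45)cc3F)ccnc2cc1OCCCN1CCC(C)CC1` has not yet been measured. It differs from compound 3 in one place: 4-methylphenyl in place of 3-methoxyphenyl on an aromatic carbon. Among the measured compounds shown here, no measured step exchanges a methoxy for a methyl on this ring, so the only direct guidance is that a methoxy-to-chloro exchange at the same ring gave a large change, and that compound 1, which carries the same 4-methylphenyl but lacks the ring fluorine, gives 880 nM. On balance compound 4 is expected to give a somewhat lower number than compound 3, a step of a 2.8-fold lower number from compound 3 to compound 4 (0.45 log units; beyond the scatter) in this assay, though the uncertainty is wide. The estimate for compound 4 is 300 nM, with a range from 60 nM to 1200 nM.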

Compound 4, half-maximal inhibitory concentration: 480 nM
Compound 4: the middle estimate sits 1.6-fold (0.20 log units) below what was measured; the range from low to high includes it.
By their numbers in this assay, from the lowest: compound 2; then compounds 4, 3 and 1 (each within the scatter of the next).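

In this assay, 4-methylphenyl in place of 3-methoxyphenyl on the aromatic carbon next to the ring nitrogen gives a 1.8-fold lower number from compound 3 to compound 4 (0.24 log units; within the scatter), so this exchange does not separate the two compounds. The same position responds far more strongly when 4-methylphenyl replaces 3-chlorophenyl, with an 8.0-fold higher number from compound 2 to compound 4 (0.90 log units; beyond the scatter), which leaves compound 2 clearly apart from both compound 3 and compound 4 and suggests that the 3-chlorophenyl group is the exception among the three aryl groups shown here. Among these compounds, the new compound also gives the first reading of the fluoro group on the shared core: fluoro in place of hydrogen, with 4-methylphenyl held constant, gives a 1.8-fold lower number from compound 1 to compound 4 (0.26 log units; within the scatter), a difference that does not exceed the usual scatter.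

The step to compound 2 changes both the substituent and its place on the phenyl ring, so the compounds shown cannot say which of the two matters, nor how an amine or a carboxylic acid on that ring would behave. Nothing shown offers an explanation for any of these differences.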